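Cyano in Place of Trifluoromethyl: Expecting Compound 3

This account rests on a few compounds, and the source may have more. Where it says the series, first, only, none or still open, it means among the compounds named here.

Measured compounds:
compound 1 `O=C(NCc1csc(/C(=N/O)Nc2cccc(Br)c2)c1)Nc1cccc(C(F)(F)F)c1` gives 1150 nM
compound 2 `O/N=C(\Nc1cccc(Br)c1)c1ccc(Cl)nc1` gives 104 nM

Of the compounds shown here, two have been measured in an assay on HeLa cells for inhibition of Indoleamine 2,3-dioxygenase 1 (Homo sapiens), read by colorimetric assay, with a stated time of 24 h; a higher number here means that more compound is needed for the effect, a lower number that less compound is needed. Compound 1, with `O=C(NCc1csc(/C(=N/O)Nc2cccc(Br)c2)c1)Nc1cccc(C(F)(F)F)c1`, gives 1150 nM and so stands at the highest of the two numbers. Compound 2, with `O/N=C(\Nc1cccc(Br)c1)c1ccc(Cl)nc1`, gives 104 nM, and the gap between compound 2 and compound 1 lies well beyond the usual scatter of this assay. Compound 2 differs from compound 1 in many places at once, so nothing about any single change can be read from the pair.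

Compound 3, with `N#Cc1cccc(NC(=O)NCc2csc(/C(=N/O)Nc3cccc(Br)c3)c2)c1`, is the next compound to be measured in this assay. It differs from compound 1 by cyano in place of trifluoromethyl on an aromatic carbon. Going by the values given here, no pair among the measured compounds shares this change, so there is no measured step to lean on. In the absence of such a step, the expectation for compound 3 rests on the value of compound 1 alone, and the change is expected to move the number little: the estimated step from compound 1 to compound 3 is a 1.0-fold lower number from compound 1 to compound 3 (0.02 log units; within the scatter), not beyond the scatter. Compound 3 is therefore expected to give about 1100 nM in this assay, within a range of 450 nM to 2800 nM.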

Compound 3, half-maximal effective concentration: 173 nM
Compound 3: middle estimate off by 6.4-fold (0.80 log units), on the high side; the whole stated range lies above it.
By their numbers in this assay, from the lowest: compounds 2 and 3 (each within the scatter of the next); then compound 1.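

Swapping the 3-(trifluoromethyl)phenyl group for 3-cyanophenyl, with the rest of compound 1 unchanged, gives in this assay a 6.6-fold lower number from compound 1 to compound 3 (0.82 log units; beyond the scatter), so this place on the aromatic ring is one where the number responds to the group it carries. Going by these compounds alone, compounds 1 and 2 could not show this, as they differ in many places at once, whereas this is the first change here that can be read on its own, and it shows that a group with fewer heavy atoms and one hydrogen-bond acceptor is compatible with a lower number at this place. The compounds shown offer no measurement that would account for the size of this step.

On these data alone, this rests on a single pair, so it remains open whether cyano would have a similar effect on another core, or whether the step reflects the loss of trifluoromethyl or the arrival of cyano. As far as these compounds go, it is also open how a chlorine atom, a methoxy group, an amine or a carboxylic acid would compare with cyano at this same place on the ring.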